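This account rests on a few compounds, and the source may have more. Where it says the series, first, only, none or still open, it means among the compounds named here.

Measured in a functional assay on IMR-32 cells (Homo sapiens) for inhibition, with a stated time of 48 h, tested at 30 uM; a higher number here means more inhibition of growth at the concentration tested, a lower number less inhibition of growth
compound 1 `C=C[C@@](C)(/C=C/c1ccc(OC(C)=O)cc1)CCC=C(C)C` gives 59%
compound 2 `C=C[C@@](C)(/C=C/c1ccc(OC(=O)CCCCCCCCC)cc1)CCC=C(C)C` gives 22%

Compound 1 stands highest of these two numbers, and compound 2 is its nearest and only neighbour. The next case is compound 3 `C=C[C@@](C)(/C=C/c1ccc(OC)cc1)CCC=C(C)C` with the change methyl in place of acetyl on an oxygen on an aromatic ring which amounts to acetoxy to methoxy on the shared core.

Going by the values given here, only one measured step bears on this change, and only indirectly. It is a number 37 percentage points lower from compound 1 to compound 2 (beyond the scatter) and it is a large step. That step alters the chain of the ester and keeps the acetyl-type carbonyl, whereas the change to compound 3 removes the acetyl altogether. Among the compounds with values here, no measured compound carries an ether on this oxygen, so the size of that step cannot simply be carried over. A step beyond the scatter is therefore not expected in this assay although the uncertainty is wide and a small fall is thought more likely than a rise. The estimated change is a number 9 percentage points lower from compound 1 to compound 3 (within the scatter) and it remains an expectation only. Compound 3 is estimated at 50% with an expected range from 25% to 75% for now.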

Compound 3, percent growth inhibition at one concentration: 23%
Estimate against measurement, compound 3: 27 percentage points above, and the stated range ends above it.
By their numbers in this assay, from the lowest: compounds 2 and 3 (each within the scatter of the next); then compound 1.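

In this assay, the oxygen on the aromatic ring responds to more than the length of an ester chain: a number 36 percentage points lower from compound 1 to compound 3 (beyond the scatter), a large step for methyl in place of acetyl. The level of compound 1 therefore does not carry over to the methoxy group, and a long ester chain is not needed for a low number at this position. Compound 2 gives 22% and compound 3 gives 23%, within the scatter of each other, so among these three compounds only the acetoxy group of compound 1 stands apart, with two quite different groups on the same oxygen both beyond the scatter from it.

No measurement in hand gives a reason for these differences.

As far as these compounds go, it remains open whether a free hydroxyl on this oxygen, or a short ester such as propanoyl or butanoyl, would stay with compound 1 or fall with compounds 2 and 3. From the compounds shown here alone, the response of a carbamate or a longer ether such as ethoxy at this oxygen is equally open, so the shape of the relationship here rests on three points only.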